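The source may report more compounds than this note shows. Statements on the series, on what has been measured and on what is new or still open speak of the compounds shown alone.

Compound 1 `CCCn1ccnc1-c1cc(OC)c(OC)c(OC)c1`: > 100000 nM (a limit)
Compound 2 `COc1cc(-c2nccn2S(=O)(=O)c2ccc(C)cc2)cc(OC)c1OC`: > 100000 nM (a limit)

Both compounds were tested in a functional assay on HCT-15 cells (Homo sapiens) for antiproliferative activity, read by MTT assay, with a stated time of 72 h; on this read-out higher numbers stand for weaker inhibition and lower numbers for stronger inhibition. Compound 1 gives > 100000 nM, which is a limit of the assay and not a number. Compound 1 therefore shares its place with compound 2: the limit of > 100000 nM in this assay, at which 2 of the 2 values shown sit. Among the compounds with values here, with no actual number for either compound, there is no measured step to use as a guide.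

The next compound is compound 3 `COc1cc(-c2nccn2-c2cccc(C)c2)cc(OC)c1OC`, which has 3-methylphenyl in place of propyl on an aromatic nitrogen. Compound 2 also carries a six-membered aromatic ring of carbon only, yet compound 2 gives > 100000 nM, again a limit, so any gain is far from certain. If this assay shows a change, stronger inhibition is the only direction it can reveal, and a modest gain is expected, though compound 3 may well stay at the limit. The estimated step is an at least 6.6-fold lower number from compound 1 to compound 3 (0.82 log units; beyond the scatter). For compound 3 the estimated value is 15000 nM, with an expected range from 1000 nM to 100000 nM.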

Compound 3, half-maximal inhibitory concentration: 1600 nM
For compound 3 the middle estimate is 9.4-fold (0.97 log units) above the measured one; low and high end bracket the measured number.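

In this assay, the step is an at least 62-fold lower number from compound 1 to compound 3 (1.79 log units; beyond the scatter), so this place on an aromatic nitrogen, next to the ring atom that bears a large group, clearly responds to the group it carries: with 3-methylphenyl instead of propyl, the read-out moves off the limit and gives a real number. Compound 2, which also carries a six-membered aromatic ring of carbon only, gives > 100000 nM, a limit of the assay and not a number, so having that ring somewhere in the substituent does not by itself ensure a measurable value. Compound 3 is therefore the only compound here with an actual number, and any conclusion rests on very little: the limit of > 100000 nM in this assay, at which 2 of the 3 values shown sit.

The compounds shown cannot tell whether the gain comes from the aromatic ring itself or from its methyl group, a question that plain phenyl would address. They also leave open whether a ring set one carbon further away, as in benzyl, or a longer chain such as hexyl would give a measurable value at this place.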